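The compounds below may be only part of what the source reports. "The series", "measured", "known", "first", "only" and "open" are said of these compounds alone.

Measured in an ADME assay on S9 fraction (Rattus norvegicus) for metabolic stability, with a stated time of 60 min; a higher number here means that more of the compound is left, a lower number that less of the compound is left:
- compound 1 `CO[C@H]1CC[C@@H](CN2CC(=O)Nc3ncc(-c4ccc(C(C)(C)O)nc4)nc32)CC1`: 39%
- compound 2 `CO[C@H]1CC[C@@H](N2CC(=O)Nc3ncc(-c4ccc(C(C)(C)O)nc4)nc32)CC1`: 87%
- compound 3 `CO[C@H]1CC[C@H](CN2CC(=O)Nc3ncc(-c4ccc(C(C)(C)O)nc4)nc32)CC1`: 77%

Compound 3 stands well clear of compound 1 and within the scatter of compound 2, as a number 10 percentage points lower from compound 2 to compound 3 (within the scatter) shows. The separation a number 38 percentage points higher from compound 1 to compound 3 (beyond the scatter) is due to the fact that compounds 1 and 3 differ only in the configuration as drawn.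

Compound 4 `CO[C@H]1CC[C@H](N2CC(=O)Nc3ncc(-c4ccc(C(C)(C)O)nc4)nc32)CC1` keeps the shared core and changes one group: 4-methoxycyclohexyl in place of (4-methoxycyclohexyl)methyl on a nitrogen on an aromatic ring in a ring. It carries 4-methoxycyclohexyl in place of (4-methoxycyclohexyl)methyl on a nitrogen on an aromatic ring in a ring.

Within the data shown here, two measured steps bear on this. The same replacement gave a large rise, a number 48 percentage points higher from compound 1 to compound 2 (beyond the scatter), but it started from the low value of compound 1. The same exchange in reverse, which also differs in configuration as drawn, stayed within the scatter: a number 10 percentage points lower from compound 2 to compound 3 (within the scatter). Compound 3, at 77%, also leaves far less room for a rise than compound 1 did at 39%.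

The expected step in this assay is therefore small and upward, not clearly beyond the scatter: a number 8 percentage points higher from compound 3 to compound 4 (within the scatter).

Compound 4 is estimated at 85%, with an expected range of 70% to 97%.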

Compound 4, percent of the compound remaining: 94%
For compound 4 the middle estimate is 9 percentage points below the measured one; the range from low to high includes it.
By their numbers in this assay, from the lowest: compound 1; then compounds 3, 2 and 4 (each within the scatter of the next, the first and the last beyond it).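

In this assay, 4-methoxycyclohexyl in place of (4-methoxycyclohexyl)methyl now gives a rise beyond the scatter even from the already high compound 3: a number 17 percentage points higher from compound 3 to compound 4 (beyond the scatter). With 4-methoxycyclohexyl, inverting the configuration stays small, a number 7 percentage points higher from compound 2 to compound 4 (within the scatter), whereas with (4-methoxycyclohexyl)methyl it gave a number 38 percentage points higher from compound 1 to compound 3 (beyond the scatter), a contrast that rests on: the fact that compounds 2 and 4 differ only in the configuration as drawn. Compound 1 is thus left alone at the low end, a number 55 percentage points higher from compound 1 to compound 4 (beyond the scatter), and the other three compounds sit in one high group, though compounds 3 and 4 are separated beyond the scatter.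

The compounds shown leave open what a longer chain on the same ring nitrogen, such as (4-methoxycyclohexyl)ethyl, would give, or an amine in place of the methoxy group. They also do not tell what happens to compound 1 during the incubation.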